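Aryl change on the pyrazole nitrogen: compound 3 to compound 4

The source may report more compounds than this note shows. Statements on the series, on what has been measured and on what is new or still open speak of the compounds shown alone.

Measured so far:
compound 1, `Cn1ncc2c(NC(=O)NCc3cc(C(C)(C)C)nn3-c3cccc(Cl)c3)cccc21`: 0.4 nM
compound 2, `O=C(NCc1cc(C(F)(F)F)nn1-c1cccc(C(F)(F)F)c1)Nc1cccc2[nH]ncc12`: 1.3 nM
compound 3, `CC(C)(C)c1cc(CNC(=O)Nc2cccc3[nH]ncc23)n(-c2cccc(F)c2)n1`: 1.3 nM

In an assay on CHO-K1 cells for antagonist activity at transient receptor potential cation channel subfamily V member 1 (Homo sapiens), read by FLIPR and calcium flux, with a stated time of 6 min (on this read-out lower numbers stand for stronger inhibition and higher numbers for weaker inhibition), compound 3 gives 1.3 nM. This is level with compound 2 at the digits shown, within the scatter, and the two together hold the highest numbers of the three. Compound 1 stands furthest off, with a lower number that lies beyond the scatter.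

Compound 4, `CC(C)(C)c1cc(CNC(=O)Nc2cccc3[nH]ncc23)n(-c2ccc(C(F)(F)F)cc2)n1`, is yet to be measured. It differs from compound 3 in one place: 4-(trifluoromethyl)phenyl in place of 3-fluorophenyl on an aromatic nitrogen. Among the measured compounds shown here, no pair of measured compounds differs in this place alone, so no measured step covers the change directly. For the measured compounds named here, what the set does show is a narrow window: compound 2, which also carries a trifluoromethyl group on its phenyl ring, gives 1.3 nM in this assay, and every number so far sits within a small span. On that basis the estimate for compound 4 in this assay is 2 nM, with a range from 0.6 nM to 7 nM. The step expected is a 1.5-fold higher number from compound 3 to compound 4 (0.19 log units; within the scatter), which would not exceed the usual scatter.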

Compound 4, inhibition constant: 19.6 nM
Compound 4: middle estimate off by 9.8-fold (0.99 log units), on the low side, outside the stated range (above it).
By their numbers in this assay, from the lowest: compound 1; then compounds 2 and 3 (each within the scatter of the next); then compound 4.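

In this assay, the aryl group on the aromatic nitrogen turns out to be a place where the number can move a long way: with the tert-butyl group and the shared core unchanged, putting 4-(trifluoromethyl)phenyl in place of 3-fluorophenyl gives a 15-fold higher number from compound 3 to compound 4 (1.18 log units; beyond the scatter), a large loss of inhibition. Among the compounds shown here, this is the first step that can be read across a single place, so the earlier compounds, none of which formed such a pair, could not show that this position tolerates so little of this change. Nothing on hand accounts for the size of the step.

The two aryl groups differ both in the group carried and in where it stands on the phenyl ring, so the step cannot yet be divided between those two changes; 4-fluorophenyl and 3-(trifluoromethyl)phenyl on the same core with the tert-butyl group would separate them. As far as these compounds go, whether a smaller or a different group in the place of the trifluoromethyl, such as methyl, methoxy or a nitrile on 4-substituted phenyl, keeps the number of compound 3 also remains open.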